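A few compounds are considered here, and "the series" means these few. Any claim that something is new, unique, unknown or untested is made for them only; others in the source may bear on it.

Of the compounds shown here, two with a shared core have been measured in an assay on isolated protein with Bile acid receptor (Homo sapiens) as the target; a higher number here means that more compound is needed for the effect, a lower number that less compound is needed. Compound 1 `COC(=O)/C=C/c1cccc(N(Cc2ccc(/C=C/c3c(C)cc(C)cc3C)cc2)C(=O)NC(C)C)c1` gives 431 nM there. Compound 2 `COC(=O)/C=C/c1cccc(N(Cc2ccc(-c3ccc(N(C)C)cc3)cc2)C(=O)C(C)C)c1` gives 57 nM and so stands at the lower of the two numbers, with the gap to compound 1 beyond the scatter. Compound 3 `COC(=O)/C=C/c1cccc(N(Cc2ccc(-c3ccc(N(C)C)cc3)cc2)C(=O)NC(C)C)c1` differs from compound 2 in one place: isopropylamino in place of isopropyl on a carbonyl carbon. Going by the values given here, no measured pair shows this change on its own, so its size is open. The expected step from compound 2 to compound 3 is a 1.8-fold higher number from compound 2 to compound 3 (0.24 log units; within the scatter), little beyond the scatter in either direction. Compound 3 is thus estimated at 100 nM, within 30 nM to 350 nM.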

Compound 3, half-maximal effective concentration: 162 nM
Beside the measured number, compound 3's estimate is 1.6-fold (0.21 log units) below it; the measured number falls inside the stated range.
By their numbers in this assay, from the lowest: compound 2; then compound 3; then compound 1.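

In this assay, going by these compounds alone, the swap of isopropyl for isopropylamino on the carbonyl carbon gives a 2.8-fold higher number from compound 2 to compound 3 (0.45 log units; beyond the scatter) and is now read directly for the first time. With isopropylamino kept, 4-(dimethylamino)phenyl in place of 2-(2,4,6-trimethylphenyl)ethenyl gives a 2.7-fold lower number from compound 1 to compound 3 (0.42 log units; beyond the scatter) and so shows that both places move the number by modest steps beyond the scatter. Nothing available explains either step. As far as these compounds go, whether the two changes add up when combined remains open. So does the outcome with methylamino on that carbonyl carbon, or with a carboxylic acid in place of the methyl ester.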